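Cyanophenyl Replacing Pyridyl: Expected Shift in Cell Tolerance

The source may report more compounds than this note shows. Statements on the series, on what has been measured and on what is new or still open speak of the compounds shown alone.

Compound 1 `N#Cc1ccc(Nc2nccc(OCc3cccnc3)n2)cc1` is the reference point of this series. Going by the values given here, in an ADME assay on MT4 cells (Homo sapiens) for cytotoxicity, read by MTT assay, with a stated time of 5 days (a higher number here means that more compound is tolerated, a lower number that less compound is tolerated), compound 1 gives 6400 nM, the lowest number among the three compounds measured so far. Compound 2 `N#Cc1ccc(Nc2nccc(OCc3cccc(Br)c3)n2)cc1` gives 221000 nM, and compound 3 `N#Cc1ccc(Nc2nccc(OCc3cc(F)ccc3Br)n2)cc1` gives 190000 nM. The step of a 1.2-fold lower number from compound 2 to compound 3 (0.07 log units; within the scatter) shows that the two substituted phenyl rings are not distinguishable in this assay.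

Compound 4 `N#Cc1ccc(Nc2nccc(OCc3cccc(C#N)c3)n2)cc1` is not yet measured. Its difference from compound 1 is 3-cyanophenyl in place of pyridin-3-yl on a saturated chain carbon bound to an oxygen on an aromatic ring. Among the compounds with values here, two measured steps bear directly on this change, since each also replaced pyridin-3-yl with a six-membered ring of carbon only bearing a single halogen: a 35-fold higher number from compound 1 to compound 2 (1.54 log units; beyond the scatter) and a 30-fold higher number from compound 1 to compound 3 (1.47 log units; beyond the scatter). Both were large rises in the same direction. The entering 3-cyanophenyl carries a nitrile rather than a halogen, a substituent not yet tested in this series, so the expected rise is set somewhat below those two steps and given a wide range. The estimated step is an 11-fold higher number from compound 1 to compound 4 (1.04 log units; beyond the scatter). Compound 4 is therefore expected to give 70000 nM, with a range from 15000 nM to 250000 nM.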

Compound 4, half-maximal cytotoxic concentration: 4100 nM
The estimate for compound 4 lay 17-fold (1.23 log units) above the measured number, and the stated range ends above it.
By their numbers in this assay, from the lowest: compounds 4 and 1 (each within the scatter of the next); then compounds 3 and 2 (each within the scatter of the next).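

At this place, on a saturated chain carbon bound to an oxygen on an aromatic ring, a ring of carbon only does not by itself bring the high numbers in this assay: with 3-cyanophenyl in place of pyridin-3-yl, the result is a 1.6-fold lower number from compound 1 to compound 4 (0.19 log units; within the scatter) and the two compounds cannot be told apart. What is on the ring matters instead, as cyano in place of bromo on an aromatic carbon gives a 54-fold lower number from compound 2 to compound 4 (1.73 log units; beyond the scatter), and replacing the 2-bromo-5-fluorophenyl ring gives a 46-fold lower number from compound 3 to compound 4 (1.67 log units; beyond the scatter). No measurement available here accounts for this difference between the nitrile and the halogens.

On these data alone, whether the low number is particular to the nitrile remains open, since only bromo and bromo with fluoro stand against it. An amine, a methoxy group or a carboxylic acid on this phenyl ring could fall on either side.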